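Amine to amide on the shared core

The source may report more compounds than this note shows. Statements on the series, on what has been measured and on what is new or still open speak of the compounds shown alone.

Measured compounds:
compound 1 `C=C1CC[C@@H]2[C@](C)(CNCc3ccccc3)[C@H](O)CC[C@@]2(C)[C@@H]1/C=C/C1=CCOC1=O` gives 960 nM
compound 2 `C=C1CC[C@@H]2[C@](C)(CNCc3ccc(Cl)cc3)[C@H](O)CC[C@@]2(C)[C@@H]1/C=C/C1=CCOC1=O` gives 420 nM
compound 3 `C=C1CC[C@@H]2[C@](C)(CNCc3ccc(C#N)cc3)[C@H](O)CC[C@@]2(C)[C@@H]1/C=C/C1=CCOC1=O` gives 1130 nM

In a functional assay on BMMC cells (Mus musculus, strain C57BL/6) for inhibition, with stated times of 5 days and 48 h (on this read-out lower numbers stand for stronger inhibition and higher numbers for weaker inhibition), compound 3 shows the highest of the three numbers; its nearest neighbour is compound 1, and that gap, a 1.2-fold higher number from compound 1 to compound 3 (0.07 log units; within the scatter), lies within the scatter, while compound 2 is furthest away, a 2.7-fold higher number from compound 2 to compound 3 (0.43 log units; beyond the scatter). Compound 4 `C=C1CC[C@H]2[C@@](C)(CC[C@@H](O)[C@@]2(C)C(=O)NCc2ccccc2)[C@@H]1/C=C/C1=CCOC1=O` differs from compound 3 by the change (a group of 10 heavy atoms (8 carbon, 1 nitrogen, 1 oxygen; one six-membered aromatic ring of carbon only) in place of a group of 11 heavy atoms (9 carbon, 2 nitrogen; one six-membered aromatic ring of carbon only), on a saturated ring carbon). Going by the values given here, no measured step covers the move from the leaving group to benzylcarbamoyl; the only step that bears on it is the loss of the cyano, the reverse of a 1.2-fold higher number from compound 1 to compound 3 (0.07 log units; within the scatter), which sits within the scatter. A step no larger than the scatter is therefore expected, a 1.1-fold lower number from compound 3 to compound 4 (0.05 log units; within the scatter), with a wide range for the untested part of the change. Compound 4 is estimated at 1000 nM, between 300 nM and 4000 nM.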

Compound 4, half-maximal inhibitory concentration: 19400 nM
The estimate for compound 4 lay 19-fold (1.29 log units) below the measured number; measured number above the stated range.
By their numbers in this assay, from the lowest: compound 2; then compounds 1 and 3 (each within the scatter of the next); then compound 4.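

In this assay, benzylcarbamoyl in place of (benzylamino)methyl on this saturated ring carbon gives a 20-fold higher number from compound 1 to compound 4 (1.31 log units; beyond the scatter) and so weakens inhibition far more than the changes on the aromatic ring did. The steps of a 46-fold higher number from compound 2 to compound 4 (1.66 log units; beyond the scatter) and a 17-fold higher number from compound 3 to compound 4 (1.23 log units; beyond the scatter) are also large, but they also remove the chloro or the cyano. This position therefore tolerates this change poorly, at least in the one amide shown.

From the compounds shown here alone, whether a tertiary amine or a longer chain between the carbonyl and the aromatic ring would restore inhibition stays open. Nothing measured here explains the loss.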